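Amide substituent and receptor binding in the shared core

The compounds below may be only part of what the source reports. "The series", "measured", "known", "first", "only" and "open" are said of these compounds alone.

Measured compounds:
compound 1 `CCOc1ccccc1C(=O)Nc1nc(-c2ccccc2)nc2c1nnn2Cc1ccccc1` 1850 nM
compound 2 `O=C(Nc1nc(-c2ccccc2)nc2c1nnn2Cc1ccccc1)C1CCCCC1` 12 nM
compound 3 `O=C(Nc1nc(-c2ccccc2)nc2c1nnn2Cc1ccccc1)c1cccc([N+](=O)[O-])c1` 77 nM

In an assay (strain Wistar) for displacement of a labelled ligand from adenosine receptor A1 (Rattus norvegicus), read by scintillation counting (a lower number here means a stronger inhibitor, a higher number a weaker inhibitor), compound 3 stands second highest of the three numbers shown. Compound 2 is nearest, with the step of a 6.4-fold higher number from compound 2 to compound 3 (0.81 log units; beyond the scatter); compound 1 is furthest, with the step of a 24-fold lower number from compound 1 to compound 3 (1.38 log units; beyond the scatter).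

Compound 4 `O=C(Nc1nc(-c2ccccc2)nc2c1nnn2Cc1ccccc1)c1ccccc1C(F)(F)F` has not been measured. Its change from compound 3 is 2-(trifluoromethyl)phenyl in place of 3-nitrophenyl on a carbonyl carbon. Among the compounds with values here, no measured step covers this exact exchange. Within the data shown here, the steps that bear on it are a 24-fold lower number from compound 1 to compound 3 (1.38 log units; beyond the scatter) and a 150-fold lower number from compound 1 to compound 2 (2.19 log units; beyond the scatter), both large, which show that the group on the carbonyl carbon moves the number strongly, and that 2-ethoxyphenyl, the other aryl group with a single substituent named with the digit 2, gave the highest number of the series. The 2-(trifluoromethyl)phenyl group of compound 4 is closer in name to the group of compound 1 than to the 3-nitrophenyl of compound 3, so in this assay a rise of the number from compound 3 is expected, though smaller than the step between compound 1 and compound 3, since nitro and trifluoromethyl also differ. The expected step is a 5.2-fold higher number from compound 3 to compound 4 (0.72 log units; beyond the scatter). For compound 4 the estimate is 400 nM, with a range from 80 nM to 2000 nM.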

Compound 4, inhibition constant: 550 nM
Compound 4: the middle estimate sits 1.4-fold (0.14 log units) below what was measured, within the range that was stated.
By their numbers in this assay, from the lowest: compound 2; then compound 3; then compound 4; then compound 1.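

In this assay the exchange of 3-nitrophenyl for 2-(trifluoromethyl)phenyl on the carbonyl carbon gives a clear rise (a 7.1-fold higher number from compound 3 to compound 4 (0.85 log units; beyond the scatter)), so a second aryl group with a single substituent named with the digit 2 also falls on the high-number side of the series. The two such groups are not equivalent: trifluoromethyl in place of ethoxy on an aromatic carbon lowers the number (a 3.4-fold lower number from compound 1 to compound 4 (0.53 log units; beyond the scatter)), so the identity of the substituent counts at this position, yet the aryl group of compound 4 remains far from cyclohexyl (a 46-fold higher number from compound 2 to compound 4 (1.66 log units; beyond the scatter)). No measurement at hand accounts for any of these steps.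

Compound 3 and compound 4 differ in both the substituent and its place on the aromatic ring, so the share of each in the rise cannot be separated from these compounds. On these data alone, how an unsubstituted phenyl, a cyclopentyl or a straight butyl chain on the carbonyl carbon would compare with cyclohexyl stays open, as does the effect of an amine or a carboxylic acid on the aromatic ring.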